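This account rests on a few compounds, and the source may have more. Where it says the series, first, only, none or still open, it means among the compounds named here.

Measured in a functional assay on HeLa cells (Homo sapiens) for cytotoxicity, read by CCK-8 assay; on this read-out higher numbers stand for weaker inhibition and lower numbers for stronger inhibition:
Compound 1 `O=C(Nc1ccc(Cl)cc1)c1ncc(-c2ccccc2)o1`: > 30000 nM
Compound 2 `O=C(c1ncc(-c2ccccc2)o1)N1CCN(c2ccccc2)CC1`: > 30000 nM

Compound 2 stands at a limit of this assay and not at a number: > 30000 nM. Compound 1 also gives a limit: > 30000 nM. Among the measured compounds shown here, the whole set so far therefore rests on (the limit of > 30000 nM in this assay, at which 2 of the 2 values shown sit), and no measured step connects the two compounds.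

Compound 3 `O=C(c1ncc(-c2ccccc2)o1)N1CCN(c2ccc(Cl)cc2)CC1` keeps the rest of compound 2 and differs in one place: chloro in place of hydrogen on an aromatic carbon, para to a large group, so that phenyl becomes 4-chlorophenyl (chloro in place of hydrogen on an aromatic carbon).

For the measured compounds named here, with no measured step to draw on, the expectation in this assay is for no change beyond the scatter, with a modest chance of stronger inhibition. Compound 1, which also carries a 4-chlorophenyl group, gives a limit and not a number: > 30000 nM. The estimated change is a number no higher from compound 2 to compound 3 (the limit leaves the size open). For compound 3 the expected value is 30000 nM, with an estimated range from 10000 nM to 60000 nM.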

Compound 3, half-maximal inhibitory concentration: > 30000 nM
Compound 3: only a limit was reported; the forecaster's own chance of this, stated with the estimate: 70%; the middle value lies on the limit itself.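

In this assay compound 3 gives a limit and not a number, > 30000 nM. Compound 2 gives a limit too, so no step can be read between compound 2 and compound 3, and the set rests on one limit: the limit of > 30000 nM in this assay, at which 3 of the 3 values shown sit.

The compounds shown leave open what chloro in place of hydrogen does to the size of the value, and which structure would give a measured number in this assay.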